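Shrinking the ring on the carbonyl carbon once more

A few compounds are considered here, and "the series" means these few. Any claim that something is new, unique, unknown or untested is made for them only; others in the source may bear on it.

Measured so far:
compound 1, `O=C(Nc1ccc2nc(NC(=O)C3CCCCC3)sc2c1)c1c(Cl)cccc1Cl`: 0.015 ug/mL
compound 2, `Cc1cc(C(=O)Nc2ccc3nc(NC(=O)C4CCCCC4)sc3c2)c(C)n1C`: > 6.2 ug/mL
compound 3, `O=C(Nc1ccc2nc(NC(=O)C3CCC3)sc2c1)c1c(Cl)cccc1Cl`: 0.013 ug/mL

In a functional assay on WI-38 VA13 cells (Homo sapiens) for cytotoxicity (on this read-out higher numbers stand for an effect only at larger amounts of compound and lower numbers for an effect already at smaller amounts), compound 1 gives 0.015 ug/mL and compound 3 gives 0.013 ug/mL; these two numbers sit within the scatter of each other, as a 1.2-fold lower number from compound 1 to compound 3 (0.06 log units; within the scatter) shows. Compound 2 gives only a limit, > 6.2 ug/mL, and not a number; this is recorded as the limit of > 6.2 ug/mL in this assay, at which 1 of the 3 values shown sits. For the measured compounds named here, the one large change among the measured steps, an at least 410-fold higher number from compound 1 to compound 2 (2.61 log units; beyond the scatter), comes from swapping the group on the other carbonyl carbon, which is not touched here.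

Compound 4, `O=C(Nc1ccc2nc(NC(=O)C3CC3)sc2c1)c1c(Cl)cccc1Cl`, differs from compound 3 by cyclopropyl in place of cyclobutyl on a carbonyl carbon. Going by the values given here, the only measured step bearing on this position, a 1.2-fold lower number from compound 1 to compound 3 (0.06 log units; within the scatter), was within the scatter, so no step beyond the scatter is expected in this assay. Compound 4 is therefore expected to give about 0.015 ug/mL, between 0.005 ug/mL and 0.05 ug/mL, an expected step of a 1.2-fold higher number from compound 3 to compound 4 (0.06 log units; within the scatter).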

Compound 4, half-maximal effective concentration: 0.013 ug/mL
Compound 4: middle estimate off by 1.2-fold (0.06 log units), on the high side; measured number inside the range.
By their numbers in this assay, from the lowest: compounds 3, 4 and 1 (each within the scatter of the next). At a limit, above all of these: compound 2.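

In this assay the move to cyclopropyl gives no change at the digits printed from compound 3 to compound 4 (within the scatter) and a 1.2-fold lower number from compound 1 to compound 4 (0.06 log units; within the scatter) and so both steps stay within the scatter. Three ring sizes on this carbonyl carbon, cyclohexyl, cyclobutyl and cyclopropyl, now read alike, which extends the earlier pair of rings down to a ring of only three carbons and shows no loss of effect at this position across compounds 1, 3 and 4. Nothing measured here explains why the ring size makes so little difference.

All three compounds carry a carbon-only ring at this position and 2,6-dichlorophenyl on the other carbonyl carbon. A methyl, an amine or a carboxylic acid in place of the ring could give quite a different reading, and the same holds for a longer chain.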